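A few compounds are considered here, and "the series" means these few. Any claim that something is new, unique, unknown or untested is made for them only; others in the source may bear on it.

Measured compounds:
compound 1, `CCC(=O)Nc1ccc(S(=O)(=O)Oc2ccccc2I)cc1`, 11000 nM
compound 2, `CCCC(=O)Nc1ccc(S(=O)(=O)Oc2ccccc2I)cc1`, 11000 nM
compound 3, `O=C(CCCl)Nc1ccc(S(=O)(=O)Oc2ccccc2I)cc1`, 14000 nM

All three numbers come from a functional assay on HT-29 cells (Homo sapiens) for antiproliferative activity, read by sulforhodamine B assay, with a stated time of 48 h; on this read-out higher numbers stand for weaker inhibition and lower numbers for stronger inhibition. Compound 3 carries the highest of the three numbers, yet it is not set apart: against compound 1 the step is a 1.3-fold higher number from compound 1 to compound 3 (0.10 log units; within the scatter), and against compound 2 it is a 1.3-fold higher number from compound 2 to compound 3 (0.10 log units; within the scatter). The two other compounds are just as close to each other, as no change at the digits printed from compound 1 to compound 2 (within the scatter) shows. The three compounds share one core and differ only in the short chain on the carbonyl carbon of the amide, and none of these changes moved the read-out beyond its scatter.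

Compound 4, `CCCCCNC(=O)Nc1ccc(S(=O)(=O)Oc2ccccc2I)cc1`, has not yet been measured. Compared with compound 3 the change is pentylamino in place of 2-chloroethyl on a carbonyl carbon. Going by the values given here, this is a larger change than the three steps already seen, which swapped only a single atom or small group on a chain carbon; still, those steps are the only guide here, and all of them stayed within the scatter. The plainest expectation is therefore no step beyond the scatter, with some added uncertainty for the bigger change.

Compound 4 is expected to give about 11000 nM, with a likely range from 4000 nM to 30000 nM, which corresponds to an estimated step of a 1.3-fold lower number from compound 3 to compound 4 (0.10 log units; within the scatter).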

Compound 4, half-maximal inhibitory concentration: 6600 nM
Compound 4: the middle estimate sits 1.7-fold (0.22 log units) above what was measured, within the range that was stated.
By their numbers in this assay, from the lowest: compounds 4, 1, 2 and 3 (each within the scatter of the next, the first and the last beyond it).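

In this assay, going by these compounds alone, this is the first change on the carbonyl carbon to reach beyond the scatter: pentylamino, with its six heavy atoms and one hydrogen-bond donor, replaces 2-chloroethyl and gives a modest step (a 2.1-fold lower number from compound 3 to compound 4 (0.33 log units; beyond the scatter)). The other two comparisons do not separate, since pentylamino in place of propyl (a 1.7-fold lower number from compound 2 to compound 4 (0.22 log units; within the scatter)) and pentylamino in place of ethyl (a 1.7-fold lower number from compound 1 to compound 4 (0.22 log units; within the scatter)) both stay within the scatter, so the step beyond it holds only against compound 3. The position therefore accepts a clearly larger group carrying a nitrogen without the read-out leaving the scatter of compound 1 and compound 2, but no measured property is at hand to account for the step from 2-chloroethyl.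

On these data alone, compound 4 adds the nitrogen and lengthens the chain in a single change, so the effect of each remains open; a hexyl chain on the carbonyl carbon or a shorter ethylamino group would help to separate them. Also open, as far as these compounds go, is how this position would respond to a ring such as piperidine or to a carboxylic acid at the end of the chain.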